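Swapping tert-Butyl for Methoxyphenyl on a Lactone Triazole

A few compounds are considered here, and "the series" means these few. Any claim that something is new, unique, unknown or untested is made for them only; others in the source may bear on it.

In a functional assay on HeLa cells (Homo sapiens) for antiproliferative activity, read by MTT assay, with a stated time of 72 h (on this read-out higher numbers stand for weaker inhibition and lower numbers for stronger inhibition), compound 2 `CC(C)(C)c1cn(C[C@H](O)[C@H]2OC(=O)C(OCc3ccccc3)=C2OCc2ccccc2)nn1` gives 18300 nM. Among the two values shown, compound 2 holds the only finite number, so it is the sole anchor for any comparison. Compound 1 `COc1ccc(-c2cn(C/C=C3\OC(=O)C(OCc4ccccc4)=C3OCc3ccccc3)nn2)cc1` reaches only a limit of the assay, recorded as > 100000 nM in this assay, a reading described by the limit of > 100000 nM in this assay, at which 1 of the 2 values shown sits, and not a measured number. Compound 3 `COc1ccc(-c2cn(C[C@H](O)[C@H]3OC(=O)C(OCc4ccccc4)=C3OCc3ccccc3)nn2)cc1` has not yet been tested; it differs from compound 2 in one place, (4-methoxyphenyl in place of tert-butyl on an aromatic carbon), that is, 4-methoxyphenyl in place of tert-butyl on an aromatic carbon of the five-membered aromatic ring with three nitrogens, two ring bonds from the ring atom that bears a large group. Among the measured compounds shown here, no measured pair shows this change on this shared core, so the direction of the step is open. The expectation is a modest loss, a step of a 1.6-fold higher number from compound 2 to compound 3 (0.21 log units; within the scatter) from compound 2 to compound 3, carried with wide uncertainty. Compound 3 is therefore estimated at 30000 nM in this assay, within a range from 6000 nM to 150000 nM, and a reading that ends only at a limit, as seen for compound 1 at > 100000 nM, remains a real possibility.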

Compound 3, half-maximal inhibitory concentration: 16400 nM
Compound 3: the middle estimate sits 1.8-fold (0.26 log units) above what was measured, and the stated range covers the measured number.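

Among the compounds shown here, the first direct comparison at this position shows that 4-methoxyphenyl in place of tert-butyl on an aromatic carbon gives a 1.1-fold lower number from compound 2 to compound 3 (0.05 log units; within the scatter) in this assay, so the two groups cannot be told apart on this shared core. The earlier compounds shown here could not show this: an open-chain tert-butyl group and a 4-methoxyphenyl group, with its six-membered aromatic ring of carbon only and its hydrogen-bond acceptor, now read alike at this carbon of the five-membered aromatic ring. Nothing measured here accounts for this equivalence, and no property of either group is on record that would explain it.

What the compounds shown leave open is whether this position stays equally indifferent to groups of another kind, such as an amine, a carboxylic acid, a longer alkyl chain or a phenyl ring without the methoxy group. They also leave open whether any group on this carbon can bring the number in this assay clearly lower, since only these two groups on the shared core have finite values to compare.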